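From Isopropyl to 2-Methoxyethyl on an Aromatic Nitrogen

The source may hold more compounds than are shown below. What is called first, only, known or untested is meant among the compounds shown, and "the series" means these compounds.

Of the compounds shown here, two have so far been measured in a physicochemical assay for solubility, read by chemiluminescence, measured as kinetic solubility; a lower number here means a less soluble compound, a higher number a more soluble compound. Compound 1 (`COc1nn(C)c2cccc(NS(=O)(=O)c3cccc(Cl)c3Cl)c12`) gives 80000 nM. Compound 2 (`COc1nn(C(C)C)c2ncnc(NS(=O)(=O)c3cccc(Cl)c3Cl)c12`) gives 404000 nM, the higher of the two numbers, and the gap between them lies beyond the scatter. These two compounds differ in more than one place, so their values cannot be tied to any single group.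

Compound 3 (`COCCn1nc(OC)c2c(NS(=O)(=O)c3cccc(Cl)c3Cl)ncnc21`) is still unmeasured. It carries 2-methoxyethyl in place of isopropyl on an aromatic nitrogen, two ring bonds from the ring atom that bears a methoxy group: 2-methoxyethyl in place of isopropyl on an aromatic nitrogen. Going by the values given here, no measured pair shows this change alone, so the data give no direct guide to its size. The expectation therefore starts from compound 2 at 404000 nM and foresees no step beyond the scatter in this assay. The estimated change is a 1.2-fold lower number from compound 2 to compound 3 (0.06 log units; within the scatter). For compound 3 the estimated value is 350000 nM, with an expected range of 150000 nM to 700000 nM.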

Compound 3, solubility: >= 442000 nM
Compound 3: no number, only a limit (the forecaster's own chance of this, stated with the estimate: 10%); middle value at least 1.2-fold (0.10 log units) from the limit.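

Until now, no single change at this position could be read, since compound 1 and compound 2 differ in more than one place. In this assay, 2-methoxyethyl in place of isopropyl on an aromatic nitrogen now gives an at least 1.0-fold higher number from compound 2 to compound 3 (0.03 log units; that floor lies within the scatter), so this step is a floor and not a measured size. Compound 3 carries a limit and not a number: the limit of >= 442000 nM in this assay, at which 1 of the 3 values shown sits.

The position therefore accepts a chain with one more heavy atom and a hydrogen-bond acceptor without the read-out falling under that floor, but how far compound 3 truly lies from compound 2 cannot be told. The compounds shown leave open whether a longer chain on this aromatic nitrogen, or one ending in an amine or a carboxylic acid, would give a number that can be read in this assay. They also leave open whether 2-methoxyethyl would produce a comparable step on the core of compound 1, where that nitrogen carries a methyl group.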